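Hydroxy Gives Way to Carboxy on the Chain Carbon

The source may hold more compounds than are shown below. What is called first, only, known or untested is meant among the compounds shown, and "the series" means these compounds.

Three compounds share one core. Compound 1 `Cc1nc2c(COc3ccccc3)cccn2c1C` and compound 2 `Cc1nc2c(C[S+]([O-])c3ccccc3)cccn2c1C` were tested in a functional assay on the whole organism with Rattus norvegicus as the target, with a stated time of 4 h, at a dose of 40 mg/kg by the intraperitoneal route; on this read-out lower numbers stand for less inhibition and higher numbers for more inhibition at the one dose given (going by the name of the read-out): compound 1 gives 48%, and compound 2 gives 42%; these two values lie within the scatter of each other. Compound 3 `Cc1nc2c(OCc3ccccc3)cccn2c1CO` gives 99% in this assay, the highest of the three numbers, standing beyond the scatter above both compound 1 and compound 2.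

Compound 4 `Cc1nc2c(OCc3ccccc3)cccn2c1CC(=O)O` has not been measured. It differs from compound 3 in one place: carboxy in place of hydroxy on a saturated chain carbon bound to an aromatic carbon. Going by the values given here, no pair of measured compounds shows a step of this kind, so nothing here sets its size. With compound 3 already close to the top of what this assay can report, the only room is downward, and the step from compound 3 to compound 4 is expected to be a number 21 percentage points lower from compound 3 to compound 4 (beyond the scatter), a modest fall that may or may not exceed the scatter. Compound 4 is therefore estimated to give 78% in this assay, within a range from 40% to 99%.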

Compound 4, a percentage reported as inhibition, in the whole organism at one dose (the size of the read-out at that dose, not a potency): 12%
Compound 4: middle estimate off by 66 percentage points, on the high side, and the stated range ends above it.
By their numbers in this assay, from the lowest: compound 4; then compounds 2 and 1 (each within the scatter of the next); then compound 3.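

Carboxy in place of hydroxy on a saturated chain carbon bound to an aromatic carbon gives the first readable step at this place, and in this assay it is large (a number 87 percentage points lower from compound 3 to compound 4 (beyond the scatter)). The high reading of compound 3 therefore depends strongly on what this chain carries: hydroxymethyl and carboxymethyl are far apart here, even though the counts of hydrogen-bond donors and acceptors stay the same across the change. No measurement available here accounts for the size of this fall.

The compounds shown leave open how an amine, an amide or a methyl ester would read at this place. They also leave open whether a longer chain ending in hydroxy or carboxy would keep or lose the inhibition seen with compound 3.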